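The source may report more compounds than this note shows. Statements on the series, on what has been measured and on what is new or still open speak of the compounds shown alone.

Measured compounds:

Compound 1, `CC(C)(C)C1=C(C(=O)O)N2C(=O)[C@H]([C@H](O)CCc3ccc(O)cc3)[C@H]2O1`: in an ADME assay, in phosphate buffer, at 28 degrees C, at pH 7.0 (on this read-out lower numbers stand for a shorter-lived compound and higher numbers for a longer-lived compound), compound 1 gives 24.6 h.
Compound 2, `CC(C)(C)C1=C(C(=O)O)N2C(=O)[C@H]([C@H](O)CCc3ccncc3)[C@H]2O1`: in this assay compound 2 gives 13.7 h.

For the measured compounds named here, compound 1 sits at the top of these two numbers, yet its only neighbour is close: the step of a 1.8-fold lower number from compound 1 to compound 2 (0.25 log units; within the scatter) does not rise above the scatter, so the two compounds cannot be told apart on this read-out.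

Compound 3, `CC(C)(C)C1=C(C(=O)O)N2C(=O)[C@H]([C@@H](O)CCc3ccc(O)cc3)[C@H]2O1`, is not yet measured. Compared with compound 1 the change is the two compounds have the same atoms and bonds and differ only in configuration as drawn: 1 of 3 stereo elements differ; a stereocentre at a saturated chain carbon is drawn R in compound 1 and S in compound 3. Going by the values given here, the single measured step, from compound 1 to compound 2, concerns an exchange of the aromatic group and says nothing about a change of configuration; no measured step bears on the present change. With no pointer in either direction, the expected step from compound 1 to compound 3 is a 1.1-fold lower number from compound 1 to compound 3 (0.05 log units; within the scatter), none beyond the scatter. Compound 3 is therefore estimated at 22 h, within a range of 9 h to 50 h.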

Compound 3, half-life: 21.2 h
Estimate against measurement, compound 3: 1.0-fold (0.02 log units) above; the measured number falls inside the stated range.
By their numbers in this assay, from the lowest: compounds 2, 3 and 1 (each within the scatter of the next).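

In this assay, the change of configuration at this saturated chain carbon gives a 1.2-fold lower number from compound 1 to compound 3 (0.06 log units; within the scatter), so the R and S forms as drawn cannot be told apart on this read-out. For the compounds shown here, the earlier step concerned only an exchange of the aromatic group, whereas this pair is the first to test this stereocentre, with the 4-hydroxyphenyl group kept in both compounds. The comparison bears on this one stereocentre alone, for this reason: the fact that compounds 1 and 3 differ only in the configuration as drawn

The compounds shown leave open whether the two configurations would also read alike with pyridin-4-yl in place of 4-hydroxyphenyl, and what a change at either of the other two stereo elements would do. They also do not show how the half-life would respond to an amine in place of the hydroxy group at this carbon, or to a longer chain.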